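Swapping methyl for bromo in compound 2

A few compounds are considered here, and "the series" means these few. Any claim that something is new, unique, unknown or untested is made for them only; others in the source may bear on it.

Measured in an ADME assay on cells (Hepatocyte, Mus musculus) for cytotoxicity, read by MTT assay, with a stated time of 24 h; a higher number here means that more compound is tolerated, a lower number that less compound is tolerated:
Compound 1 `FC(F)(F)c1ccc(-c2nn(-c3ccccc3)cc2-c2nc3ccccc3[nH]2)cc1`: 159000 nM
Compound 2 `Cc1ccc(-c2nn(-c3ccccc3)cc2-c2nc3ccccc3n2S(=O)(=O)c2ccc(C)cc2)cc1`: 102000 nM

Compound 2, at 102000 nM, cannot be told apart from compound 1, at 159000 nM, given the usual scatter of such measurements. Compound 3 `Cc1ccc(-c2nn(-c3ccccc3)cc2-c2nc3ccccc3n2S(=O)(=O)c2ccc(Br)cc2)cc1` changes compound 2 in one place: bromo in place of methyl on an aromatic carbon, para to a large group (bromo in place of methyl on an aromatic carbon). Going by the values given here, no measured pair shows this swap, so the expectation rests on compound 2 alone. In this assay the expected size is a 1.0-fold lower number from compound 2 to compound 3 (0.01 log units; within the scatter), with nothing beyond the scatter and no direction favoured. For compound 3 the estimated value is 100000 nM, with a range of 50000 nM to 210000 nM.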

Compound 3, half-maximal cytotoxic concentration: > 300000 nM
Compound 3: a limit, no number; the forecaster's own chance of this, stated with the estimate: 15%; at least 3.0-fold (0.47 log units) between middle value and limit.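

Until now nothing showed that this aromatic carbon, para to a large group, mattered in this assay. Bromo in place of methyl there, a swap of one heavy atom for one heavy atom, gives an at least 2.9-fold higher number from compound 2 to compound 3 (0.46 log units; beyond the scatter). The value of compound 3 is a limit of the assay and not a number: the limit of > 300000 nM in this assay, at which 1 of the 3 values shown sits.

Still open, on these data alone, is how much of compound 3 is actually tolerated. Also open, as far as these compounds go, is whether chloro, methoxy or an amine on the same carbon would behave like bromo or like methyl.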